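The source may report more compounds than this note shows. Statements on the series, on what has been measured and on what is new or still open speak of the compounds shown alone.

Measured so far:
compound 1, `COc1ccc2c(/C=C/C(=O)c3cc(OC)c(OC)c([N+](=O)[O-])c3)c[nH]c2c1`, 742 nM in a functional assay on A2780 cells (Homo sapiens) for antiproliferative activity, read by MTT assay, with a stated time of 48 h; on this read-out higher numbers stand for weaker inhibition and lower numbers for stronger inhibition
compound 2, `COc1cc(C(=O)/C=C/c2c[nH]c3ccccc23)cc([N+](=O)[O-])c1OC`, 1280 nM in this assay
compound 3, `COc1ccc2c(/C=C/C(=O)c3cc(OC)c(OC)c(SC)c3)cn(C)c2c1`, 145 nM in this assay

Compound 3 gives the lowest number of the three in this assay; its steps to compound 1 and compound 2 both lie beyond the scatter. How the core of compound 3 differs from the core of compound 1 is not broken down here.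

Compound 1 and compound 2 differ in one place, (hydrogen in place of methoxy on an aromatic carbon). That change gave a 1.7-fold higher number from compound 1 to compound 2 (0.24 log units; within the scatter), a step within the scatter.

Compound 4, `COc1cc(C(=O)/C=C/c2cn(C)c3ccccc23)cc(SC)c1OC`, is not yet measured. It differs from compound 3 by hydrogen in place of methoxy on an aromatic carbon. The place line for this change reads word for word as for the change from compound 1 to compound 2, so it is the same change, applied now on the core of compound 3.

The expectation for compound 4 rests on one earlier example: the step of a 1.7-fold higher number from compound 1 to compound 2 (0.24 log units; within the scatter). The step from compound 3 to compound 4 in this assay is therefore expected to be of similar size, a 1.7-fold higher number from compound 3 to compound 4 (0.24 log units; within the scatter). Compound 4 is estimated at 250 nM in this assay, expected to fall between 120 nM and 550 nM.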

Compound 4, half-maximal inhibitory concentration: 193 nM
Compound 4: middle estimate off by 1.3-fold (0.11 log units), on the high side, within the range that was stated.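

With hydrogen in place of methoxy on the aromatic carbon, this assay gives a 1.3-fold higher number from compound 3 to compound 4 (0.12 log units; within the scatter), so the step on the core of compound 3 is again small. Set beside the earlier example, the two steps agree: the same change on two cores in this assay, a 1.7-fold higher number (0.24 log units; within the scatter) from compound 1 to compound 2 and a 1.3-fold higher number (0.12 log units; within the scatter) from compound 3 to compound 4, 1.3-fold (0.11 log units) apart, within the scatter of two such steps. This shows that the change carries across these two cores without a step beyond the scatter, so in this assay the methoxy can be exchanged for hydrogen on either core with no clear shift in the number, but it does not show that the methoxy has any effect of its own, and two pairs give no rule for the series as a whole.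

The compounds shown leave open how another group on this aromatic carbon, such as an amine, a carboxylic acid or a longer alkoxy chain, would behave in this assay. They also leave open whether the step stays this small on cores other than those of compound 1 and compound 3.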